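The compounds below may be only part of what the source reports. "The series", "measured", "known", "first", "only" and "open" are said of these compounds alone.

Measured compounds:
Compound 1, `Cn1c(-c2ccc(NC(=O)CCl)cc2)nc(-c2ccccc2)c1-c1ccccc1`, gives 3.4% in a functional assay on MCF7 cells (Homo sapiens) for cytotoxicity, read by MTT assay, with a stated time of 24 h, tested at 0.64 ug/mL; on this read-out lower numbers stand for a weaker effect and higher numbers for a stronger effect at the one concentration tested.
Compound 2, `CN1CCN(CC(=O)Nc2ccc(-c3nc(-c4ccccc4)c(-c4ccccc4)n3C)cc2)CC1`, gives 1.1%.
Compound 3, `Cn1c(-c2ccc(NC(=O)CN3CCN(c4ccccc4)CC3)cc2)nc(-c2ccccc2)c1-c1ccccc1`, gives 12.1%.

All three share one core and differ only in the group carried on the saturated chain carbon bound to the carbonyl carbon. Compound 3 sits at the top of these three numbers, but the gap is uneven: a number 8.7 percentage points higher from compound 1 to compound 3 (within the scatter), whereas a number 11 percentage points higher from compound 2 to compound 3 (beyond the scatter).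

Compound 4, `Cc1ccc(CN2CCN(CC(=O)Nc3ccc(-c4nc(-c5ccccc5)c(-c5ccccc5)n4C)cc3)CC2)cc1`, has not yet been measured. It differs from compound 3 in one place: 4-methylbenzyl in place of phenyl on an amine nitrogen in a ring. Among the compounds with values here, the only measured step that touches this ring nitrogen is the exchange of methyl for phenyl, a number 11 percentage points higher from compound 2 to compound 3 (beyond the scatter), a modest gain. Within the data shown here, no measured step exchanges phenyl for 4-methylbenzyl, so the direction of this change is not settled by the data. Among the measured compounds shown here, with only a modest effect from the one related step, and the other steps within the scatter, a step of no clear size beyond the scatter is expected, a number 2.1 percentage points lower from compound 3 to compound 4 (within the scatter). Compound 4 is therefore estimated at 10%, with a range from 2% to 22%.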

Compound 4, a percentage reported as activity, at one concentration (the size of the read-out at that concentration, not a potency): 9.4%
The estimate for compound 4 lay 0.6 percentage points above the measured number, and the stated range covers the measured number.
By their numbers in this assay, from the lowest: compounds 2, 1, 4 and 3 (each within the scatter of the next, the first and the last beyond it).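

In this assay, the ring nitrogen also accepts 4-methylbenzyl, with its 8 heavy atoms against the 6 of phenyl, and the step is a number 2.7 percentage points lower from compound 3 to compound 4 (within the scatter), so these two groups cannot be told apart here. Against methyl on the same nitrogen, the step is a number 8.3 percentage points higher from compound 2 to compound 4 (within the scatter), so compound 4 also cannot be separated from compound 2, even though compound 2 and compound 3 do differ beyond the scatter. No measurement available here explains these readings.

From the compounds shown here alone, it remains open whether a plain benzyl group, or a hydrogen on this ring nitrogen, would give a reading apart from these compounds, and the same goes for a carboxylic acid on the benzyl ring. Each reading comes from a single concentration, so none of them describes potency.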